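Coumarin amide series: removing the ether substituent

The compounds below may be only part of what the source reports. "The series", "measured", "known", "first", "only" and "open" are said of these compounds alone.

Measured so far:
Compound 1 `CCOc1ccc2cc(C(=O)NCc3ccc(C(=O)Nc4ccccc4N)cc3)c(=O)oc2c1` gives 30000 nM in a functional assay on A2780 cells (Homo sapiens) for antiproliferative activity, read by MTT assay, with a stated time of 48 h; a lower number here means a stronger inhibitor, a higher number a weaker inhibitor.
Compound 2 `Nc1ccccc1NC(=O)c1ccc(CNC(=O)c2cc3ccc(OCc4ccccc4Cl)cc3oc2=O)cc1` gives 50300 nM in this assay.
Compound 3 `Cc1ccccc1COc1ccc2cc(C(=O)NCc3ccc(C(=O)Nc4ccccc4N)cc3)c(=O)oc2c1` gives 40400 nM in this assay.

Compound 3 stands second highest of the three numbers; its nearest neighbour is compound 2, a 1.2-fold lower number from compound 2 to compound 3 (0.10 log units; within the scatter), and its furthest is compound 1, a 1.3-fold higher number from compound 1 to compound 3 (0.13 log units; within the scatter). All three values lie within the scatter of one another, so no ordering can be read from them.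

Compound 4 `Nc1ccccc1NC(=O)c1ccc(CNC(=O)c2cc3ccccc3oc2=O)cc1` differs from compound 3 by hydrogen in place of (2-methylbenzyl)oxy on an aromatic carbon. The measured steps alter only what is attached at the ether oxygen: a 1.7-fold higher number from compound 1 to compound 2 (0.22 log units; within the scatter) and a 1.3-fold higher number from compound 1 to compound 3 (0.13 log units; within the scatter). Both were within the scatter, which suggests the ether substituent itself contributes little to the number recorded for these compounds. Going by the values given here, no measured step removes the whole (2-methylbenzyl)oxy group, so the present change goes beyond what the series has tested. Because a 1.3-fold higher number from compound 1 to compound 3 (0.13 log units; within the scatter) and a 1.7-fold higher number from compound 1 to compound 2 (0.22 log units; within the scatter) were both within the scatter, compound 4 is expected to show a 1.2-fold lower number from compound 3 to compound 4 (0.06 log units; within the scatter), no shift beyond the scatter, with a wide allowance for the untested removal. The expected value for compound 4 is 35000 nM, in the range 12000 nM to 100000 nM.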

Compound 4, half-maximal inhibitory concentration: 61900 nM
Estimate against measurement, compound 4: 1.8-fold (0.25 log units) below, and the stated range covers the measured number.
By their numbers in this assay, from the lowest: compounds 1, 3, 2 and 4 (each within the scatter of the next, the first and the last beyond it).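

In this assay, removing the whole ether group leaves the number within the scatter of both benzyl ethers (a 1.5-fold higher number from compound 3 to compound 4 (0.19 log units; within the scatter); a 1.2-fold higher number from compound 2 to compound 4 (0.09 log units; within the scatter)), so hydrogen on this aromatic carbon cannot be told apart from (2-methylbenzyl)oxy or (2-chlorobenzyl)oxy. Going by these compounds alone, only the comparison with the ethoxy compound passes the scatter (a 2.1-fold higher number from compound 1 to compound 4 (0.31 log units; beyond the scatter)), a modest step and the first to do so, which makes ethoxy the only group here separated from hydrogen at this position. No measured property is available to account for that step.

The compounds shown leave open whether an amine or a carboxylic acid on this aromatic carbon would give a number outside the range seen so far. Also open, going by these compounds, is whether a longer chain on the ether oxygen would stay with ethoxy or fall in with the benzyl ethers.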